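Bromo in Place of Acetyl on the Phenyl Ring

The compounds below may be only part of what the source reports. "The series", "measured", "known", "first", "only" and "open" are said of these compounds alone.

Of the compounds shown here, three sharing one core have been measured in a functional assay on SF-268 cells (Homo sapiens) for inhibition, read by sulforhodamine B assay, with a stated time of 48 h, tested at 10 uM; on this read-out lower numbers stand for less inhibition and higher numbers for more inhibition at the one concentration tested (going by the name of the read-out). Compound 1 `c1ccc(-c2cn3ccnc3c(-c3ccc4ncn(C5CCCCC5)c4c3)n2)cc1` gives 21.7%, compound 2 `O=Cc1ccc(-c2cn3ccnc3c(-c3ccc4ncn(C5CCCCC5)c4c3)n2)cc1` gives 27.1%, and compound 3 `CC(=O)c1ccc(-c2cn3ccnc3c(-c3ccc4ncn(C5CCCCC5)c4c3)n2)cc1` gives 5.01%. Compound 3 stands lowest of the three, with compound 1 nearest and compound 2 furthest. The steps show this: a number 16.7 percentage points lower from compound 1 to compound 3 (beyond the scatter) and a number 22.1 percentage points lower from compound 2 to compound 3 (beyond the scatter), while a number 5.4 percentage points higher from compound 1 to compound 2 (within the scatter) stays within the scatter.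

Compound 4 `Brc1ccc(-c2cn3ccnc3c(-c3ccc4ncn(C5CCCCC5)c4c3)n2)cc1` differs from compound 3 in one place: bromo in place of acetyl on an aromatic carbon. Among the compounds with values here, no measured step introduces bromo, so the bearing evidence is indirect. Within the data shown here, the only step that removes acetyl, a number 16.7 percentage points lower from compound 1 to compound 3 (beyond the scatter), was modest and beyond the scatter, and the untouched ring in compound 1 sat near the middle of the three numbers. Compound 4 is therefore expected to return toward the level of compound 1, an estimated step of a number 15 percentage points higher from compound 3 to compound 4 (beyond the scatter). Compound 4 is estimated at 20%, within a range from 5% to 38%.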

Compound 4, a percentage reported as inhibition, at one concentration (the size of the read-out at that concentration, not a potency): 15.5%
The estimate for compound 4 lay 4.5 percentage points above the measured number, within the range that was stated.
By their numbers in this assay, from the lowest: compound 3; then compounds 4, 1 and 2 (each within the scatter of the next, the first and the last beyond it).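

In this assay, exchanging acetyl for bromo on this aromatic carbon gives a number 10.5 percentage points higher from compound 3 to compound 4 (beyond the scatter) and so shows that the low reading of the 4-acetylphenyl compound does not extend to every group placed here. Bromo also parts from formyl, with a number 11.6 percentage points lower from compound 2 to compound 4 (beyond the scatter) at the same place, whereas the comparison with the unsubstituted ring gives a number 6.2 percentage points lower from compound 1 to compound 4 (within the scatter) and leaves bromo indistinguishable from hydrogen here. Nothing available accounts for these steps.

The compounds shown leave open whether an amine, a carboxylic acid or a longer chain on this carbon would read nearer to compound 2 or to compound 3. They also leave open whether chloro or methoxy would fall with bromo and hydrogen or apart from them.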